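The source may report more compounds than this note shows. Statements on the series, on what has been measured and on what is new or still open speak of the compounds shown alone.

Measured in a functional assay on ileum (Cavia porcellus) for antagonist activity (on this read-out lower numbers stand for stronger inhibition and higher numbers for weaker inhibition), so far:
- compound 1 `COc1ccc(OCCCOc2ccc3c(O)c([N+](=O)[O-])c(=O)oc3c2)cc1` gives > 4000 nM as a limit
- compound 2 `O=c1oc2cc(OCCCOc3ccc(-c4ccccc4)cc3)ccc2c(O)c1[N+](=O)[O-]` gives > 20000 nM as a limit
- compound 3 `O=C(O)c1ccc(OCCCOc2ccc3c(O)c([N+](=O)[O-])c(=O)oc3c2)cc1` gives > 20000 nM as a limit

Compound 3 stands at > 20000 nM as a limit and not a number. Among the measured compounds shown here, the series so far offers only limits, namely the limit of > 20000 nM in this assay, at which 2 of the 3 values shown sit, and the limit of > 4000 nM in this assay, at which 1 of the 3 values shown sits, as the second.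

Compound 4 `CC(=O)c1ccc(OCCCOc2ccc3c(O)c([N+](=O)[O-])c(=O)oc3c2)cc1O` is not yet measured. It carries 4-acetyl-3-hydroxyphenyl in place of 4-carboxyphenyl on an oxygen on a saturated carbon, counted in full as 4-acetyl-3-hydroxyphenyl in place of 4-carboxyphenyl on an oxygen on a saturated carbon here.

The measured steps that bear on this change are substitutions on the aromatic ring that leaves: a step that the two limits leave unreadable from compound 1 to compound 3 and a step that the two limits leave unreadable from compound 2 to compound 3 and also a step that the two limits leave unreadable from compound 1 to compound 2 as the third. None of them has a readable size, so none sets a size or direction for this assay in this step. A weak result close to those limits is expected, quite possibly another limit.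

The expected step is an at least 2.0-fold lower number from compound 3 to compound 4 (0.30 log units; that floor lies within the scatter) and remains a loose estimate. For compound 4 the estimated value is 10000 nM (expected range 2000 nM to 40000 nM).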

Compound 4, half-maximal inhibitory concentration: 2800 nM
The estimate for compound 4 lay 3.6-fold (0.55 log units) above the measured number; low and high end bracket the measured number.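

In this assay, 4-acetyl-3-hydroxyphenyl on an oxygen on a saturated carbon gives the series its first readable number, with compound 4 at 2800 nM. In place of 4-carboxyphenyl it gives an at least 7.1-fold lower number from compound 3 to compound 4 (0.85 log units; beyond the scatter), so the read-out does respond to a change at this position, by an amount beyond the scatter. In place of 4-methoxyphenyl it gives only an at least 1.4-fold lower number from compound 1 to compound 4 (0.15 log units; that floor lies within the scatter), which does not separate the two compounds, and the steps among compound 1, compound 2 and compound 3 cannot be read.

The compounds shown leave open whether the acetyl or the hydroxy of the entering group accounts for the step, as the two appear only together. Also open, going by these compounds, is how an amine on the same ring, or a longer chain in place of the present link to the shared core, would read in this assay.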